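A few compounds are considered here, and "the series" means these few. Any claim that something is new, unique, unknown or untested is made for them only; others in the source may bear on it.

The three measured compounds share one core and differ only in the chain carried on the saturated ring carbon. Compound 1 `Cn1ncc(Cl)c1-c1cc(C(=O)N[C@@H]2CN[C@H](CCn3cncn3)C[C@H]2c2ccc(Cl)c(Cl)c2)oc1Cl` gives 1560 nM in a functional assay on OVCAR-8 cells (Homo sapiens) for antiproliferative activity; on this read-out lower numbers stand for stronger inhibition and higher numbers for weaker inhibition. Compound 3 `Cn1ncc(Cl)c1-c1cc(C(=O)N[C@@H]2CN[C@H](CCN3CCCC3)C[C@H]2c2ccc(Cl)c(Cl)c2)oc1Cl` gives 1840 nM in this assay; the step of a 1.2-fold higher number from compound 1 to compound 3 (0.07 log units; within the scatter) shows that exchanging one ring-bearing chain end for another leaves the read-out unchanged within the scatter. Compound 2 `Cn1ncc(Cl)c1-c1cc(C(=O)N[C@@H]2CN[C@H](CCO)C[C@H]2c2ccc(F)c(F)c2)oc1Cl` gives 460 nM in this assay and stands lowest of the three numbers, beyond the scatter from both of the others.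

Compound 4 `CNC(=O)C[C@@H]1C[C@@H](c2ccc(F)c(F)c2)[C@H](NC(=O)c2cc(-c3c(Cl)cnn3C)c(Cl)o2)CN1` is not yet measured. It departs from compound 2 by methylcarbamoyl in place of hydroxymethyl on a saturated chain carbon bound to a saturated ring carbon; seen one bond further out, 2-hydroxyethyl becomes (methylcarbamoyl)methyl. Among the measured compounds shown here, no measured step mirrors this change: the only step available, from compound 1 to compound 3, concerns a different chain end and a different pair of halogens on the aryl ring, and it was within the scatter. That sole precedent suggests that alterations at this chain end tend to shift this assay little, so the step of a 1.4-fold higher number from compound 2 to compound 4 (0.15 log units; within the scatter) is expected to be modest, if anything toward a slightly higher number. Compound 4 is therefore estimated at 650 nM, with a range from 250 nM to 1700 nM.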

Compound 4, half-maximal inhibitory concentration: 800 nM
For compound 4 the middle estimate is 1.2-fold (0.09 log units) below the measured one; the range from low to high includes it.
By their numbers in this assay, from the lowest: compounds 2, 4, 1 and 3 (each within the scatter of the next, the first and the last beyond it).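

Among the compounds shown here, with the fluorine-bearing aryl ring of compound 2 held fixed, the step of a 1.7-fold higher number from compound 2 to compound 4 (0.24 log units; within the scatter) in this assay gives the first reading at this chain end for an open-chain, non-ring group, as the earlier step of a 1.2-fold higher number from compound 1 to compound 3 (0.07 log units; within the scatter) exchanged only one ring-bearing chain end for another. It shows that methylcarbamoyl can replace hydroxymethyl on a saturated chain carbon bound to a saturated ring carbon with a difference still within the scatter, even though the entering group has more heavy atoms and adds a double bond outside aromatic rings, while the counts of hydrogen-bond donors and acceptors stay the same. Nothing shown gives a measured basis for explaining this outcome.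

The compounds shown leave open how a carboxylic acid, a primary amide, a simple amine or a longer chain would read at this position on the same core. For the compounds shown here, they also leave open whether the pair of halogens on the aryl ring affects the read-out, since no two compounds here differ in that place alone.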